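Alpha-ketoheterocycle series: methoxy for trifluoromethyl on the oxazole carbon

A few compounds are considered here, and "the series" means these few. Any claim that something is new, unique, unknown or untested is made for them only; others in the source may bear on it.

Three compounds share the phenylalkyl ketone chain and differ in the five-membered ring attached to the carbonyl. Compound 1 `O=C(CCCCCCc1ccccc1)c1nnc(-c2ccccc2)s1` and compound 2 `O=C(CCCCCCc1ccccc1)c1nnc(-c2ccccc2)[nH]1` carry aryl-substituted rings; compound 3 `O=C(CCCCCCc1ccccc1)c1nc(C(F)(F)F)co1` carries the trifluoromethyl-bearing ring. In an assay on HEK-293T cells for inhibition of diacylglycerol lipase-alpha (Homo sapiens), read by colorimetric assay (a higher number here means a weaker inhibitor, a lower number a stronger inhibitor), compound 1 gives > 10000 nM, which is a limit of the assay and not a number. Compound 2 likewise gives > 10000 nM, again a limit. Within the data shown here, compound 3 gives 214 nM, the only actual number in the set; the other two results sit at the limit of > 10000 nM in this assay, at which 2 of the 3 values shown sit, so compound 3 cannot be ranked against them beyond noting that it alone falls within the measurable range.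

The next compound, compound 4 `COc1coc(C(=O)CCCCCCc2ccccc2)n1`, keeps the whole chain and the ring of compound 3 and changes a single substituent: methoxy in place of trifluoromethyl on an aromatic carbon, at the position next to the ring nitrogen and two ring bonds from the ring oxygen. Among the measured compounds shown here, no measured pair in the set makes this exact change, so the expectation rests on compound 3 alone. A step in this assay beyond the scatter, toward weaker inhibition, is expected, giving an estimated 7.0-fold higher number from compound 3 to compound 4 (0.85 log units; beyond the scatter). Compound 4 is therefore expected to come in at about 1500 nM, with a plausible range from 300 nM to 8000 nM.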

Compound 4, half-maximal inhibitory concentration: > 10000 nM
Compound 4: no number, only a limit; the forecaster's own chance of this, stated with the estimate: 25%; middle value at least 6.6-fold (0.82 log units) away from the limit.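

In this assay, among these compounds, methoxy in place of trifluoromethyl on an aromatic carbon, next to the ring nitrogen, gives an at least 46-fold higher number from compound 3 to compound 4 (1.66 log units; beyond the scatter), which is the only comparison in this set that differs in one place. With the chain and the ring held fixed, this shows that the measurable inhibition of compound 3 does not survive this single exchange, so the substituent at this position matters in its own right, something compounds 1 and 2 could not show because they differ from compound 3 in the ring itself. Compound 4 gives > 10000 nM, which is a limit of the assay and not a number, so the step has a lower bound but no upper end: the limit of > 10000 nM in this assay, at which 3 of the 4 values shown sit.

Going by these compounds, whether a chlorine atom, a nitrile or a methyl group at this position would keep the inhibition seen with compound 3 stays open. Also open, on these data alone, are which difference between trifluoromethyl and methoxy carries the step, and how far beyond the limit compound 4 actually lies.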